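Methyl on the sulfonamide phenyl ring: working notes

The source may hold more compounds than are shown below. What is called first, only, known or untested is meant among the compounds shown, and "the series" means these compounds.

Three compounds sharing one core have numbers in a functional assay on MCF7 cells (Homo sapiens) for antiproliferative activity, read by MTT assay, with a stated time of 72 h; on this read-out higher numbers stand for weaker inhibition and lower numbers for stronger inhibition. Compound 1 (`Cc1ccc(N(C)S(=O)(=O)C2CC3OC2C(c2ccc(NC(=O)CCCCCCC(=O)O)cc2)=C3c2ccc(O)cc2)cc1`) gives 23200 nM, compound 2 (`COc1cccc(N(C)S(=O)(=O)C2CC3OC2C(c2ccc(NC(=O)CCCCCCC(=O)O)cc2)=C3c2ccc(O)cc2)c1`) gives 39400 nM, and compound 3 (`CCN(c1ccccc1)S(=O)(=O)C1CC2OC1C(c1ccc(NC(=O)CCCCCCC(=O)O)cc1)=C2c1ccc(O)cc1`) gives 19100 nM. Compound 3 separates only from compound 2, and modestly: a 2.1-fold lower number from compound 2 to compound 3 (0.31 log units; beyond the scatter). Against compound 1 it shows no order: a 1.2-fold lower number from compound 1 to compound 3 (0.08 log units; within the scatter).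

Next is compound 4 (`CCN(c1ccc(C)cc1)S(=O)(=O)C1CC2OC1C(c1ccc(NC(=O)CCCCCCC(=O)O)cc1)=C2c1ccc(O)cc1`), with methyl in place of hydrogen on an aromatic carbon, para to a large group: methyl in place of hydrogen on an aromatic carbon. This turns ethyl(phenyl)amino into ethyl(4-methylphenyl)amino.

Going by the values given here, no measured pair isolates this change. The closest evidence is the step between compound 1 and compound 3, which differs in the same ring methyl but also exchanges methyl for ethyl on the nitrogen, and it stays within the scatter. The aryl exchange is also small: a 1.7-fold higher number from compound 1 to compound 2 (0.23 log units; within the scatter). No step beyond the scatter is therefore expected in this assay, in either direction. The estimated step is a 1.0-fold higher number from compound 3 to compound 4 (0.02 log units; within the scatter). The estimate for compound 4 is 20000 nM, with an expected range of 11000 nM to 36000 nM.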

Compound 4, half-maximal inhibitory concentration: 42300 nM
Estimate against measurement, compound 4: 2.1-fold (0.33 log units) below, outside the stated range (above it).
By their numbers in this assay, from the lowest: compounds 3, 1, 2 and 4 (each within the scatter of the next, the first and the last beyond it).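

In this assay, going by these compounds alone, methyl in place of hydrogen on the aromatic carbon now stands alone, with ethyl on the sulfonamide nitrogen in both compounds, and the step is modest but beyond the scatter (a 2.2-fold higher number from compound 3 to compound 4 (0.35 log units; beyond the scatter)); the earlier compounds showed this ring methyl only together with a change on the nitrogen. With 4-methylphenyl held constant, methyl in place of hydrogen on the saturated chain carbon gives no order (a 1.8-fold higher number from compound 1 to compound 4 (0.26 log units; within the scatter)), and neither does the exchange of the whole amino group (a 1.1-fold higher number from compound 2 to compound 4 (0.03 log units; within the scatter)). Nothing available bears on the reason for the ring-methyl step.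

Open, from the compounds shown here alone, is whether a chlorine, a fluorine or a methoxy group at the same place would give a similar step. Also open, going by these compounds, is whether ring methyl has the same effect when methyl, or a longer chain such as propyl, sits on the sulfonamide nitrogen.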